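This account rests on a few compounds, and the source may have more. Where it says the series, first, only, none or still open, it means among the compounds named here.

Notes on the series. Compound 1 `CC(=O)Nc1cccc(-c2ccc(CO)cc2)c1` is the starting point for the step considered here. In an assay for binding affinity to 17-beta-hydroxysteroid dehydrogenase type 2 (Homo sapiens), with a stated time of 20 min, tested at 1 uM (a lower number here means less inhibition, a higher number more inhibition at the concentration tested (going by the name of the read-out)), compound 1 gives < 10%, which is a limit of the assay and not a number. Compound 2 `O=C(Nc1cccc(-c2ccc(CO)cc2)c1)c1ccccc1` carries phenyl in place of methyl on a carbonyl carbon. In this assay compound 2 gives < 10%, again a limit of the assay rather than a number. Among the measured compounds shown here, the one measured step, a step that the two limits leave unreadable from compound 1 to compound 2, stays unreadable because of the limit of < 10% in this assay, at which 2 of the 2 values shown sit. For the measured compounds named here, compound 1 therefore stands only at a limit in this assay, and the single further value shown is a limit as well.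

Compound 3 `CC(=O)Nc1cccc(-c2ccc(O)cc2)c1` is the compound to be measured next. It differs from compound 1 by hydroxy in place of hydroxymethyl on an aromatic carbon. Going by the values given here, no measured step touches this position, and the only step available is of unreadable size, so it gives no direction for the change. The expectation for compound 3 in this assay rests on compound 1 standing at < 10%. For compound 3 the estimated step is a step that the limit leaves unreadable from compound 1 to compound 3, none beyond the scatter. The value expected for compound 3 is 8%, in the range 0% to 25%.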

Compound 3, a percentage reported as inhibition, at one concentration (the size of the read-out at that concentration, not a potency): < 10%
Compound 3: no number, only a limit (the forecaster's own chance of this, stated with the estimate: 60%); the middle value does not contradict the limit.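

No new step can be read from compound 1 to compound 3 in this assay, because each compound stands at a limit of the assay and not at a number: the limit of < 10% in this assay, at which 3 of the 3 values shown sit. The compounds shown leave open whether hydroxy or hydroxymethyl on the aromatic carbon, or phenyl or methyl on the carbonyl carbon, makes any difference to inhibition.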